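Removing One Bromo Group on a Shared Core

A few compounds are considered here, and "the series" means these few. Any claim that something is new, unique, unknown or untested is made for them only; others in the source may bear on it.

Three compounds share one core and differ only in the groups carried on a single aromatic ring. Compound 1 `COC(=O)c1c(Br)cc(Br)cc1OC(=O)COc1cc(O)c2c(=O)cc(-c3ccccc3)oc2c1` gives 45700 nM in a functional assay on cells (T-cell, Mus musculus, strain BALB/c) for inhibition, read by MTT assay, with a stated time of 72 h (on this read-out higher numbers stand for weaker inhibition and lower numbers for stronger inhibition), the highest of the three numbers, though within the scatter of compound 2 `COC(=O)c1cccc(C)c1OC(=O)COc1cc(O)c2c(=O)cc(-c3ccccc3)oc2c1` at 39100 nM and of compound 3 `COC(=O)c1c(Cl)cccc1OC(=O)COc1cc(O)c2c(=O)cc(-c3ccccc3)oc2c1` at 38900 nM. Going by the values given here, the one step known between neighbours, a 1.0-fold lower number from compound 2 to compound 3 (0.00 log units; within the scatter), shows that changing groups on this ring left the number where it was. Compound 4 `COC(=O)c1ccc(Br)cc1OC(=O)COc1cc(O)c2c(=O)cc(-c3ccccc3)oc2c1` differs from compound 1 by hydrogen in place of bromo on an aromatic carbon. Since this change also sits on that ring, no movement beyond the scatter is expected: compound 4 is estimated at 42000 nM, between 20000 nM and 90000 nM, that is a 1.1-fold lower number from compound 1 to compound 4 (0.04 log units; within the scatter).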

Compound 4, half-maximal inhibitory concentration: 17600 nM
Estimate against measurement, compound 4: 2.4-fold (0.38 log units) above, and the stated range ends above it.
By their numbers in this assay, from the lowest: compound 4; then compounds 3, 2 and 1 (each within the scatter of the next).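

Bromo on this aromatic carbon does matter, although the earlier ring changes had left the number unmoved: in this assay, hydrogen in its place gives a modest step beyond the scatter (a 2.6-fold lower number from compound 1 to compound 4 (0.41 log units; beyond the scatter)). The result also separates this compound from the two with other ring groups (a 2.2-fold lower number from compound 3 to compound 4 (0.34 log units; beyond the scatter) and a 2.2-fold lower number from compound 2 to compound 4 (0.35 log units; beyond the scatter)). Nothing measured here explains the shift.

Still open, on these data alone, is whether hydrogen is special at this aromatic carbon. An amine or a carboxylic acid there could lower the number further, leave it alone or raise it.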